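Adding a methyl to a saturated ring carbon of compound 1

A few compounds are considered here, and "the series" means these few. Any claim that something is new, unique, unknown or untested is made for them only; others in the source may bear on it.

Compound 1 `COc1cc(OC)cc(C(=O)NC2CCN(Cc3ccc4ccccc4c3)CC2)c1` gives 27 nM in an assay on isolated protein for binding affinity to melanin-concentrating hormone receptor 1 (Homo sapiens); on this read-out higher numbers stand for weaker inhibition and lower numbers for stronger inhibition. Of the two numbers measured here it is the lower one; the nearest is compound 2 `COc1cc(C(=O)NC2CCN(Cc3ccc4ccccc4c3)CC2)cc(OC)c1OC`, which gives 286 nM, reached by an 11-fold higher number from compound 1 to compound 2 (1.03 log units; beyond the scatter). Compound 3 `COc1cc(OC)cc(C(=O)NC2(C)CCN(Cc3ccc4ccccc4c3)CC2)c1` differs from compound 1 by methyl in place of hydrogen on a saturated ring carbon. For the measured compounds named here, the only measured step alters a group on an aromatic ring, not on the saturated ring, so it says nothing direct about this change. The step expected is a 1.5-fold higher number from compound 1 to compound 3 (0.17 log units; within the scatter), small and of uncertain direction. For compound 3 the estimated value is 40 nM, between 8 nM and 200 nM.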

Compound 3, inhibition constant: 86 nM
Compound 3: the middle estimate sits 2.2-fold (0.33 log units) below what was measured; the measured number falls inside the stated range.
By their numbers in this assay, from the lowest: compound 1; then compound 3; then compound 2.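

For the compounds shown here, until now, the only measured change was on an aromatic ring; this result shows that the number also responds to a change on the saturated ring. In this assay, methyl in place of hydrogen on this saturated ring carbon, three ring bonds from the ring nitrogen, gives a 3.2-fold higher number from compound 1 to compound 3 (0.50 log units; beyond the scatter), so even this one added carbon weakens inhibition modestly. Nothing measured here gives a reason for this shift. From the compounds shown here alone, it remains open whether a longer chain such as ethyl on this carbon would widen the step, or whether a hydroxyl group or an amine there would behave like methyl.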